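Sulfonyl for carbonyl on a nitrogen on an aromatic ring

The source may hold more compounds than are shown below. What is called first, only, known or untested is meant among the compounds shown, and "the series" means these compounds.

Three compounds of the series share one core and differ only in the group carried on the ring nitrogen. Compound 1 `O=C(/C=C/c1cccc(NC(=O)c2ccccc2Cl)c1)c1nc2ccccc2[nH]1` gives 4570 nM in a functional assay on MCF7 cells (Homo sapiens) for antiproliferative activity, read by MTT assay, with a stated time of 48 h; on this read-out lower numbers stand for stronger inhibition and higher numbers for weaker inhibition. Compound 2 `O=C(Nc1cccc(/C=C/C(=O)c2nc3ccccc3[nH]2)c1)c1cccc(Br)c1` gives 5210 nM, and compound 3 `COc1cccc(C(=O)Nc2cccc(/C=C/C(=O)c3nc4ccccc4[nH]3)c2)c1` gives 17800 nM. Compound 3 stands at the highest number of the three: the step of a 3.9-fold higher number from compound 1 to compound 3 (0.59 log units; beyond the scatter) and the step of a 3.4-fold higher number from compound 2 to compound 3 (0.53 log units; beyond the scatter) both lie beyond the scatter, while the step of a 1.1-fold higher number from compound 1 to compound 2 (0.06 log units; within the scatter) does not.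

Compound 4 `Cc1ccc(S(=O)(=O)Nc2cccc(/C=C/C(=O)c3nc4ccccc4[nH]3)c2)cc1` differs from compound 3 by (4-methylphenyl)sulfonyl in place of (3-methoxyphenyl)carbonyl on a nitrogen on an aromatic ring. Every measured step changes only the substituent on the ring attached to the carbonyl; none exchanges the carbonyl itself for a sulfonyl, so the measured steps bear on this change only through the spread they show across the three compounds, a spread that is modest in size. Within the data shown here, with no direct precedent, no step beyond the scatter in either direction is expected for compound 4, and the estimate is set near compound 3 with a range wide enough to cover the spread of the three measured compounds: compound 4 is expected at 12000 nM, between 3000 nM and 45000 nM, which would mean an expected step of a 1.5-fold lower number from compound 3 to compound 4 (0.17 log units; within the scatter).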

Compound 4, half-maximal inhibitory concentration: 3220 nM
Compound 4: the middle estimate sits 3.7-fold (0.57 log units) above what was measured; low and high end bracket the measured number.
By their numbers in this assay, from the lowest: compounds 4, 1 and 2 (each within the scatter of the next); then compound 3.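

At this nitrogen on an aromatic ring, the carbonyl is not needed to keep the antiproliferative read-out of this assay in the range of compounds 1 and 2: (4-methylphenyl)sulfonyl in compound 4 gives a number that cannot be separated from either of them (a 1.6-fold lower number from compound 2 to compound 4 (0.21 log units; within the scatter); a 1.4-fold lower number from compound 1 to compound 4 (0.15 log units; within the scatter)). Against compound 3 the exchange does register (a 5.5-fold lower number from compound 3 to compound 4 (0.74 log units; beyond the scatter)), so the position accepts a sulfonyl as well as a carbonyl, and among the compounds shown only compound 3 stands apart. No measurement available here bears on the reason for this result.

Every step to compound 4 changes the carbonyl to a sulfonyl and alters the substituent on the attached ring at once, so the share of each in the step from compound 3 remains unresolved. A pair such as (4-methylphenyl)carbonyl and (3-methoxyphenyl)sulfonyl on this nitrogen would separate the two changes, while methylsulfonyl would show whether the sulfonyl needs an aromatic ring on it at all.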